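Cytotoxicity on MT4 cells: piperazine linkage variants

The source may hold more compounds than are shown below. What is called first, only, known or untested is meant among the compounds shown, and "the series" means these compounds.

Measured so far:
compound 1 `Cc1cc(/C=C/C#N)cc(C)c1Oc1nc(Nc2ccc(CN3CCNCC3)cc2)nc2sccc12`, 4030 nM
compound 2 `Cc1cc(/C=C/C#N)cc(C)c1Oc1nc(Nc2ccc(N3CCNCC3)cc2)nc2ccsc12`, 5730 nM
compound 3 `Cc1cc(/C=C/C#N)cc(C)c1Oc1nc(Nc2ccc(N3CCN(S(C)(=O)=O)CC3)cc2)nc2ccsc12`, 11500 nM

In an ADME assay on MT4 cells (Homo sapiens) for cytotoxicity, read by MTT assay, with a stated time of 5 days (a higher number here means that more compound is tolerated, a lower number that less compound is tolerated), compound 1 gives the lowest of the three numbers. Its nearest neighbour is compound 2, and the two values lie within the scatter of each other; compound 3 sits further away, beyond the scatter. Among the measured compounds shown here, the only step measured in one place is a 2.0-fold higher number from compound 2 to compound 3 (0.30 log units; within the scatter).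

Compound 4 `Cc1cc(/C=C/C#N)cc(C)c1Oc1nc(Nc2ccc(N3CCNCC3)cc2)nc2sccc12` is not yet measured. It differs from compound 1 by piperazin-1-yl in place of (piperazin-1-yl)methyl on an aromatic carbon. For the measured compounds named here, no measured step covers this change directly. Compound 2 carries the same piperazin-1-yl group on the same aromatic carbon but differs from compound 4 elsewhere in the shared core, so its value in this assay is the closest point of reference, and compound 1 and compound 2 are within the scatter of each other. The expectation is therefore no step beyond the scatter, a 1.2-fold higher number from compound 1 to compound 4 (0.09 log units; within the scatter). Compound 4 is estimated at 5000 nM, with a range from 2500 nM to 10000 nM.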

Compound 4, half-maximal cytotoxic concentration: 4740 nM
Compound 4: the middle estimate sits 1.1-fold (0.02 log units) above what was measured; the range from low to high includes it.
By their numbers in this assay, from the lowest: compounds 1, 4, 2 and 3 (each within the scatter of the next, the first and the last beyond it).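

In this assay, piperazin-1-yl in place of (piperazin-1-yl)methyl on the aromatic carbon, para to a large group, gives a 1.2-fold higher number from compound 1 to compound 4 (0.07 log units; within the scatter). Among the compounds shown here, this is the first direct reading of this change, as the only earlier step concerned the ring amine nitrogen rather than the group on the aromatic carbon. On the core of compound 1, the change from 7 to 6 heavy atoms therefore leaves the read-out within the scatter. No data on hand explain this result.

Going by these compounds, a longer chain, such as a two-carbon ethylene link between the aromatic ring and the piperazine, remains open at this position, as does a morpholine ring in place of the piperazine. The compounds shown also do not tell whether methylsulfonyl on the ring nitrogen would behave on the core of compound 4 as it does in the step from compound 2 to compound 3.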